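A few compounds are considered here, and "the series" means these few. Any claim that something is new, unique, unknown or untested is made for them only; others in the source may bear on it.

Measured so far:
- compound 1, `COc1cccc(CNCCCNc2ccnc3cc(Oc4ccc(Cl)cc4)ccc23)c1O`: in an ADME assay on HepG2 cells (Homo sapiens) for cytotoxicity, read by luminescence, CellTiter-Glo and ATP content, with a stated time of 72 h (on this read-out lower numbers stand for an effect already at smaller amounts and higher numbers for an effect only at larger amounts of compound), compound 1 gives 5700 nM
- compound 2, `COc1ccc(F)cc1CNCCCNc1ccnc2cc(CC(C)C)ccc12`: in this assay compound 2 gives 2900 nM

Two compounds of the series carry a number in this assay. Compound 1 sits at the top of the two numbers, but the gap to compound 2 lies within the scatter, so no ranking between compound 1 and compound 2 can be read from these two values; compound 2 differs from compound 1 in more than one place, so nothing is counted as a step between them.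

Compound 3, `COc1cccc(CNCCCNc2ccnc3cc(CC4CCCCC4)ccc23)c1O`, is not yet measured. It differs from compound 1 in one place: cyclohexylmethyl in place of 4-chlorophenoxy on an aromatic carbon

For the measured compounds named here, no step between measured compounds is available to calibrate this change. Against that background, the expectation for compound 3 in this assay is a step from compound 1 of a 1.4-fold lower number from compound 1 to compound 3 (0.15 log units; within the scatter), leaning toward a lower number but not beyond the scatter. Compound 3 is estimated at 4000 nM, with a range from 1500 nM to 11000 nM.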

Compound 3, half-maximal effective concentration: 970 nM
Compound 3: the middle estimate sits 4.1-fold (0.62 log units) above what was measured, outside the stated range (below it).
By their numbers in this assay, from the lowest: compound 3; then compounds 2 and 1 (each within the scatter of the next).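

Working notes on the series: at this position, on an aromatic carbon meta to a fused ring and para to a fused ring, a single exchange now produces a separable difference in this assay, with a 5.9-fold lower number from compound 1 to compound 3 (0.77 log units; beyond the scatter) for cyclohexylmethyl in place of 4-chlorophenoxy. For the compounds shown here, the two earlier numbers could not be ranked, so this is the first evidence that the group at this place can shift the read-out beyond the scatter. The exchange replaces an aromatic ring with a non-aromatic ring and also removes the oxygen and chlorine, and this one step cannot show which of these differences matters, while no measurement shown here accounts for the shift.

The compounds shown leave open how the read-out would respond at this position to a morpholine, a carboxylic acid or a longer alkyl chain. Going by these compounds alone, they also leave open whether the same exchange would give a step of similar size when the rest of the molecule is changed, since the series offers this single step so far.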